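From 2-chlorophenyl to 4-methylphenyl on the ring nitrogen

This account rests on a few compounds, and the source may have more. Where it says the series, first, only, none or still open, it means among the compounds named here.

Three analogues of one core have been tested in a functional assay on COLO 205 cells (Homo sapiens) for cytotoxicity, read by MTT assay, with a stated time of 48 h; on this read-out lower numbers stand for stronger inhibition and higher numbers for weaker inhibition. Compound 1 `COc1ccc(Nc2nc(-c3cccc(F)c3)nc3ccc(F)cc23)cc1` gives 46800 nM. Compound 2 `Fc1cccc(-c2nc(Nc3cccc(Cl)c3)c3cc(F)ccc3n2)c1` reaches only a limit, > 50000 nM. Compound 3 `Fc1cccc(-c2nc(Nc3ccccc3Cl)c3cc(F)ccc3n2)c1` likewise stops at a limit, > 50000 nM. Two of the three values therefore sit at the limit of > 50000 nM in this assay, at which 2 of the 3 values shown sit, so compound 3 stands no better than weak. The steps read an at least 1.0-fold higher number from compound 1 to compound 2 (0.02 log units; that floor lies within the scatter) and an at least 1.0-fold higher number from compound 1 to compound 3 (0.02 log units; that floor lies within the scatter), while a step that the two limits leave unreadable from compound 2 to compound 3. Compound 4 `Cc1ccc(Nc2nc(-c3cccc(F)c3)nc3ccc(F)cc23)cc1` differs from compound 3 by 4-methylphenyl in place of 2-chlorophenyl on a nitrogen on an aromatic ring. For the measured compounds named here, since no measured step here is readable beyond the scatter, compound 4 is expected to stay weak, with a number no higher from compound 3 to compound 4 (the limit leaves the size open). The estimate for compound 4 in this assay is 50000 nM, within 15000 nM to 150000 nM, and a limit rather than a number is quite possible.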

Compound 4, half-maximal inhibitory concentration: > 50000 nM
Compound 4: only a limit was reported; the forecaster's own chance of this, stated with the estimate: 55%; the middle value lies on the limit itself.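

In this assay compound 4 also stops at a limit, > 50000 nM. The steps from compound 2 and compound 3 to compound 4 cannot be read, and at this position methyl in place of methoxy on an aromatic carbon gives an at least 1.0-fold higher number from compound 1 to compound 4 (0.02 log units; that floor lies within the scatter). A simple methyl on the phenyl ring therefore adds no readable change, and the series still gathers at one limit: the limit of > 50000 nM in this assay, at which 3 of the 4 values shown sit.

Still open, from the compounds shown here alone, is whether another group on this phenyl ring, such as a carboxylic acid or a dimethylamino group, gives a number clear of that limit. Changes elsewhere on the shared core remain equally open.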